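This account rests on a few compounds, and the source may have more. Where it says the series, first, only, none or still open, it means among the compounds named here.

Working notes on the series. Two compounds have numbers in an assay on isolated protein for inhibition of Amine oxidase [flavin-containing] B (Homo sapiens); on this read-out lower numbers stand for stronger inhibition and higher numbers for weaker inhibition. Compound 1 `CN(C)c1ccc(/C=C2\COc3ccccc3C2=O)cc1` gives 8510 nM in this assay. Compound 2 `COc1ccc(C(=O)/C=C/c2ccc(Cl)cc2)cc1` gives 53700 nM in this assay, the highest of the two numbers, and its nearest neighbour is compound 1 with a lower number by a gap that lies beyond the scatter. Going by the values given here, no pair differing in a single place has yet been measured, so the only step on record is a comparison across two different cores.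

Compound 3 `COc1ccc(C(=O)/C=C/c2ccc(OCc3ccccc3)cc2)cc1` has not been measured. It differs from compound 2 in one place: benzyloxy in place of chloro on an aromatic carbon. Among the compounds with values here, no measured step bears on this change, so the expectation rests on the weak number of compound 2 alone. For compound 3 a step of a 9.0-fold lower number from compound 2 to compound 3 (0.95 log units; beyond the scatter) toward stronger inhibition is expected. Compound 3 is estimated at 6000 nM in this assay, with a range from 1200 nM to 30000 nM.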

Compound 3, half-maximal inhibitory concentration: 447000 nM
For compound 3 the middle estimate is 75-fold (1.87 log units) below the measured one, outside the stated range (above it).
By their numbers in this assay, from the lowest: compound 1; then compound 2; then compound 3.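

In this assay the series now has its first single-place step, an 8.3-fold higher number from compound 2 to compound 3 (0.92 log units; beyond the scatter), and it runs toward weaker inhibition. The value at this aromatic carbon, para to a large group, therefore depends on the substituent, and replacing chloro with benzyloxy, which brings in a second six-membered aromatic ring of carbon only and a hydrogen-bond acceptor, gives a change beyond the scatter. No measurement on hand accounts for this step.

Going by these compounds alone, with only two groups compared here, it remains open whether the loss follows from the size of benzyloxy, its oxygen, or its added ring. Fluoro, a hydroxyl or a carboxylic acid at the same carbon could help separate these, and whether the same change has a similar effect on the core of compound 1 is also unresolved.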